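The source may report more compounds than this note shows. Statements on the series, on what has been measured and on what is new or still open speak of the compounds shown alone.

In an assay on the whole organism (plasma, strain Sprague-Dawley) for inhibition of Dipeptidyl peptidase 4 (Rattus norvegicus), with a stated time of 6 h, at a dose of 1 mg/kg by the oral route (a lower number here means less inhibition, a higher number more inhibition at the dose given (going by the name of the read-out)), compound 1 `CCCNC(=O)[C@@H]1CN[C@H](C(=O)N2CCC[C@H]2C#N)C1` gives 59%, while compound 2 `N#C[C@@H]1CCCN1C(=O)[C@@H]1CCCN1` gives 20%. Compound 2 stands lowest of the two numbers, and the step of a number 39 percentage points lower from compound 1 to compound 2 (beyond the scatter) shows what the propylcarbamoyl group contributes to the shared core. Compound 3 `N#C[C@@H]1CCCN1C(=O)[C@@H]1C[C@H](C(=O)N2CCC2)CN1` returns a group to the same saturated ring carbon: (azetidin-1-yl)carbonyl in place of hydrogen on a saturated ring carbon. For the measured compounds named here, the one relevant step is the loss of propylcarbamoyl, a number 39 percentage points lower from compound 1 to compound 2 (beyond the scatter), which was large. The entering group is also a carbonyl attached to a nitrogen, so a rise of similar kind is expected, though not necessarily of the same size, since no other amide variant has been measured. The expected step is a number 30 percentage points higher from compound 2 to compound 3 (beyond the scatter), upward and beyond the scatter. Compound 3 is therefore estimated to give 50%, with a range from 30% to 70% in this assay.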

Compound 3, a percentage reported as inhibition, in the whole organism at one dose (the size of the read-out at that dose, not a potency): 77%
Estimate against measurement, compound 3: 27 percentage points below; measured number outside the range, above it.
By their numbers in this assay, from the lowest: compound 2; then compound 1; then compound 3.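

In this assay the saturated ring carbon takes a second carbonyl-linked group with a large gain, a rise of a number 57 percentage points higher from compound 2 to compound 3 (beyond the scatter) and so the benefit seen earlier is not tied to propylcarbamoyl alone. The group on the carbonyl carbon also matters, since azetidin-1-yl in place of propylamino gives a number 18 percentage points higher from compound 1 to compound 3 (beyond the scatter) and so changing only this part of the substituent moves the number beyond the scatter. No measurement on hand bears on what lies behind either step.

From the compounds shown here alone, whether a group with no carbonyl at this carbon, such as a simple amine or a carboxylic acid, would raise the number too remains open. Going by these compounds, it is equally open whether a larger ring such as pyrrolidin-1-yl or a short chain such as methylamino on the carbonyl carbon would go further or fall back.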